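Nitroaniline Replaces Methoxyphenyl on a Fused Aromatic Core

The source may hold more compounds than are shown below. What is called first, only, known or untested is meant among the compounds shown, and "the series" means these compounds.

Measured compounds:
compound 1, `Cc1nc2c3ccccc3ccc2c2nc3c(ccc4ccccc43)c(-c3nccnc3N)c12`: 47.8 ug/mL
compound 2, `COc1ccc(-c2c3ccc4ccccc4c3nc3c2c(C)nc2c4ccccc4ccc32)cc1`: 82.3 ug/mL

Two compounds share a fused core and differ only in the aryl group attached to one aromatic carbon. In a functional assay, read by spectrophotometry, with a stated time of 15 min (a lower number here means a stronger inhibitor, a higher number a weaker inhibitor), compound 1, carrying 3-aminopyrazin-2-yl, gives 47.8 ug/mL, and compound 2, carrying 4-methoxyphenyl, gives 82.3 ug/mL. Among the compounds with values here, compound 2 has the higher of the two numbers, but its only neighbour is compound 1, and the step of a 1.7-fold higher number from compound 1 to compound 2 (0.24 log units; within the scatter) is within the scatter, so no order between them can be claimed.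

Compound 3 `Cc1nc2c3ccccc3ccc2c2nc3c(ccc4ccccc43)c(-c3cc([N+](=O)[O-])ccc3N)c12` is the next member of the series. Its change relative to compound 2 is 2-amino-5-nitrophenyl in place of 4-methoxyphenyl on an aromatic carbon. Within the data shown here, the single measured step that bears on this exchange is a 1.7-fold higher number from compound 1 to compound 2 (0.24 log units; within the scatter), in which one aryl group replaced another on the same carbon without moving the number beyond the scatter. Like 3-aminopyrazin-2-yl in compound 1, the entering 2-amino-5-nitrophenyl carries an amine, which suggests a number close to what has already been seen. The step of a 1.5-fold lower number from compound 2 to compound 3 (0.18 log units; within the scatter) is therefore expected to stay within the scatter. The estimate for compound 3 in this assay is 55 ug/mL, with a range from 25 ug/mL to 120 ug/mL.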

Compound 3, half-maximal inhibitory concentration: 43.3 ug/mL
Beside the measured number, compound 3's estimate is 1.3-fold (0.10 log units) above it; the range from low to high includes it.
By their numbers in this assay, from the lowest: compounds 3, 1 and 2 (each within the scatter of the next).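

In this assay, placing 2-amino-5-nitrophenyl on the aromatic carbon opposite the ring nitrogen gives a 1.9-fold lower number from compound 2 to compound 3 (0.28 log units; within the scatter), so a third aryl group at this position, one carrying a hydrogen-bond donor and more hydrogen-bond acceptors than 4-methoxyphenyl, still yields no step beyond the scatter. The exchange of one amine-bearing aryl group for another gives a 1.1-fold lower number from compound 1 to compound 3 (0.04 log units; within the scatter), which shows that 3-aminopyrazin-2-yl and 2-amino-5-nitrophenyl cannot be told apart here, even though one has a ring of carbon only. All three aryl groups now stand within the scatter of one another, and no supporting evidence is available to explain this flat result.

Going by these compounds, it remains open whether the amine or the nitro group of 2-amino-5-nitrophenyl has any bearing on the number, since the two appear only together in compound 3. On these data alone, it is also open whether a group of a different kind at this position, such as a carboxylic acid or a longer chain ending in an amine, would give a step beyond the scatter.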